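Phenyl Replaces Methyl on a Piperazine Sulfonamide

The source may report more compounds than this note shows. Statements on the series, on what has been measured and on what is new or still open speak of the compounds shown alone.

For the measured compounds named here, compound 1 `CCCn1c(=O)[nH]c2nc(-c3ccc(S(=O)(=O)N4CCN(C)CC4)cc3)[nH]c2c1=O` gives 7% in an assay on CHO cells for displacement of a labelled ligand from adenosine receptor A3 (Homo sapiens), read by scintillation counting, with a stated time of 45 min, tested at 1 uM, in the presence of a further agent that is not named here (on this read-out higher numbers stand for more inhibition at the one concentration tested (going by the name of the read-out) and lower numbers for less inhibition), which places it second highest of the three numbers so far. Compound 3 `CCCn1c(=O)[nH]c2nc(-c3ccc(S(=O)(=O)N4CCN(c5ccccc5)C(C)C4)cc3)[nH]c2c1=O` gives -2%, within the scatter of compound 1. Going by the values given here, compound 2 `CCCn1c(=O)[nH]c2nc(-c3ccc(S(=O)(=O)N4CCN(c5cccc(F)c5)CC4)cc3)[nH]c2c1=O` gives 44%, and the one-place step a number 37 percentage points higher from compound 1 to compound 2 (beyond the scatter) is the only measured change that bears on the present question. The new compound 4 `CCCn1c(=O)[nH]c2nc(-c3ccc(S(=O)(=O)N4CCN(c5ccccc5)CC4)cc3)[nH]c2c1=O` differs from compound 1 by phenyl in place of methyl on an amine nitrogen in a ring. Since the related step to compound 2 was large and upward, a sizeable rise is expected, though a smaller one, as compound 4 lacks the fluorine of compound 2. The expected step is a number 23 percentage points higher from compound 1 to compound 4 (beyond the scatter). Compound 4 is therefore estimated at 30%, between 5% and 55%.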

Compound 4, a percentage reported as inhibition, at one concentration (the size of the read-out at that concentration, not a potency): 27%
The estimate for compound 4 lay 3 percentage points above the measured number; measured number inside the range.
By their numbers in this assay, from the lowest: compounds 3 and 1 (each within the scatter of the next); then compound 4; then compound 2.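

Phenyl on the ring nitrogen is enough on its own to raise the number in this assay (a number 20 percentage points higher from compound 1 to compound 4 (beyond the scatter)), so the gain at this position does not need the fluoro of the 3-fluorophenyl group. That fluoro still counts, as its removal brings the number down (a number 17 percentage points lower from compound 2 to compound 4 (beyond the scatter)). The saturated ring carbon matters too, as hydrogen in place of the methyl there gives a clear rise (a number 29 percentage points higher from compound 3 to compound 4 (beyond the scatter)).

Going by these compounds, how a benzyl group on that nitrogen, or chloro in place of the fluoro, would compare remains open. No measurement here explains any of these steps.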